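The compounds below may be only part of what the source reports. "The series", "measured", "known", "first", "only" and "open" are said of these compounds alone.

Compound 1 `CC(C)COc1ccccc1-c1ncc(C(=O)O)c(=O)[nH]1` is the reference point here. In a functional assay on the whole organism (strain Sprague-Dawley) for inhibition, with Rattus norvegicus as the target, with a stated time of 10 min (on this read-out lower numbers stand for an effect already at smaller amounts and higher numbers for an effect only at larger amounts of compound), compound 1 gives 0.5 mg/kg and stands highest of the two numbers recorded. The nearest is compound 2 `O=C(O)c1cnc(-c2ccccc2OCC2CC2)[nH]c1=O`, which gives 0.1 mg/kg in this assay, a change of a 5.0-fold lower number from compound 1 to compound 2 (0.70 log units; beyond the scatter). Compound 3 `CSc1ccccc1-c1ncc(C(=O)O)c(=O)[nH]1` reaches only a limit of the assay, > 20 mg/kg (the limit of > 20 mg/kg in this assay, at which 1 of the 3 values shown sits). The step of an at least 40-fold higher number from compound 1 to compound 3 (1.60 log units; beyond the scatter) and the step of an at least 200-fold higher number from compound 2 to compound 3 (2.30 log units; beyond the scatter) both run to that limit.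

Compound 4 `CCOC(=O)c1cnc(-c2ccccc2OCC(C)C)[nH]c1=O` differs from compound 1 by ethyl in place of hydrogen on an oxygen next to a carbonyl group, so that carboxy becomes ethoxycarbonyl. None of the three measured steps bears on this position: each of them changes the group on the aromatic carbon, isobutoxy, cyclopropylmethoxy or methylsulfanyl, and leaves the carboxy group untouched. The measured steps therefore give no direct guide, and the expectation is kept close to compound 1 with a wide range. Compound 4 is estimated at 1 mg/kg in this assay, between 0.3 mg/kg and 5 mg/kg. This estimate for compound 4 means an expected step of a 2.0-fold higher number from compound 1 to compound 4 (0.30 log units; within the scatter), not beyond the scatter.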

Compound 4, dose for 50% inhibition: 3 mg/kg
Compound 4: the middle estimate sits 3.0-fold (0.48 log units) below what was measured, and the stated range covers the measured number.
By their numbers in this assay, from the lowest: compound 2; then compound 1; then compound 4. At a limit, above all of these: compound 3.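

Within the data shown here, changing carboxy to ethoxycarbonyl gives the first reading at this position: in this assay the ethyl in place of hydrogen on the oxygen gives a 6.0-fold higher number from compound 1 to compound 4 (0.78 log units; beyond the scatter), a modest step beyond the scatter. The free carboxy hydrogen is therefore not essential for a measurable effect here, as compound 4 still gives a number rather than a limit, yet the change does carry a cost on this read-out. Nothing measured in this series accounts for the size of this step.

Whether compound 4 acts as the ester itself or through the carboxy form cannot be told from these data. Also open, going by these compounds, are how a primary amide or a longer chain such as butyl would read at this position, and whether the ethyl step carries over to compound 2 with its cyclopropylmethoxy group.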